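The source may hold more compounds than are shown below. What is called first, only, known or untested is meant among the compounds shown, and "the series" means these compounds.

In an ADME assay on HepG2 2.2.15 cells (Homo sapiens) for cytotoxicity (a lower number here means that less compound is tolerated, a higher number that more compound is tolerated), compound 1 `O=c1[nH]c2ccc(Cl)cc2c(-c2ccccc2Cl)c1CCO` gives 388000 nM, and compound 2 `CS(=O)(=O)OCCc1c(Cl)nc2ccc(Cl)cc2c1-c1ccccc1Cl` gives 882000 nM. Compound 3 `CC(C)(C)[Si](CCc1c(OCc2c(F)cccc2F)nc2ccc(Cl)cc2c1-c1ccccc1Cl)(c1ccccc1)c1ccccc1` gives > 1860000 nM in this assay, and this is a limit of the measurement rather than a number. Its standing is told by the limit of > 1860000 nM in this assay, at which 1 of the 3 values shown sits. Compound 4 `CC(C)(C)[Si](CCc1c(OCc2c(Cl)cccc2Cl)nc2ccc(Cl)cc2c1-c1ccccc1Cl)(c1ccccc1)c1ccccc1` is the next compound, and it differs from compound 3 by 2,6-dichlorophenyl in place of 2,6-difluorophenyl on a saturated chain carbon bound to an oxygen on an aromatic ring. Among the measured compounds shown here, no two measured compounds here differ in a single place, so no measured step is available for comparison. The step from the measured value to the estimate, an at least 1.1-fold lower number from compound 3 to compound 4 (0.06 log units; that floor lies within the scatter), is expected to be no larger than the usual scatter, in either direction. Compound 4 is therefore estimated at 1600000 nM in this assay, within a range from 600000 nM to 3500000 nM.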

Compound 4, half-maximal cytotoxic concentration: > 1020000 nM
Compound 4 gave a limit, no number; the forecaster's own chance of this, stated with the estimate: 60%; the middle value lies beyond the limit too.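

Compound 3 and compound 4 each gave only a limit of the measurement and no number, so the step between them cannot be read. In this assay the compounds shown leave open whether 2,6-dichlorophenyl in place of 2,6-difluorophenyl changes the tolerated concentration at all.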